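The source may report more compounds than this note shows. Statements on the series, on what has been measured and on what is new or still open speak of the compounds shown alone.

Three compounds built on a shared core have been examined in a functional assay on B16-BL6 cells (Mus musculus) for cytotoxicity, read by MTT assay, with a stated time of 48 h; a higher number here means a weaker inhibitor, a lower number a stronger inhibitor. Compound 1, `CNC(=O)c1ccc(Sc2ccc(NC(=O)Nc3ccc(Cl)c(C(F)(F)F)c3)cc2)nc1`, gives 24600 nM in this assay. Compound 3, `CNC(=O)c1ccc(Sc2ccc(NC(=O)Nc3ccc(F)c(C(F)(F)F)c3)cc2)nc1`, gives 39600 nM in this assay. The two differ by a single change, (chloro in place of fluoro on an aromatic carbon), and the step of a 1.6-fold lower number from compound 3 to compound 1 (0.21 log units; within the scatter) is small enough to sit within the usual scatter of such measurements, so the two values cannot be ranked against each other. Compound 2, `CNC(=O)c1ccc(Sc2ccc(NC(=S)Nc3ccc(F)c(C(F)(F)F)c3)cc2)nc1`, gives 29300 nM in this assay. Its value lies close to that of compound 1 and also close to that of compound 3, with every gap within the scatter. How the core of compound 2 differs from the core of compound 3 is not broken down here.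

Compound 4, `CNC(=O)c1ccc(Sc2ccc(NC(=S)Nc3ccc(Cl)c(C(F)(F)F)c3)cc2)nc1`, is not yet measured. Relative to compound 2 it carries the change (chloro in place of fluoro on an aromatic carbon), which is the same change as the one made from compound 3 to compound 1, at the same place in the same surroundings. For the measured compounds named here, since that earlier change produced only the step of a 1.6-fold lower number from compound 3 to compound 1 (0.21 log units; within the scatter), the step from compound 2 to compound 4 is expected to be of similar size, namely a 1.5-fold lower number from compound 2 to compound 4 (0.19 log units; within the scatter). On this basis compound 4 is estimated to give 19000 nM in this assay, with a likely range from 9000 nM to 40000 nM.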

Compound 4, half-maximal inhibitory concentration: 23500 nM
Compound 4: the middle estimate sits 1.2-fold (0.09 log units) below what was measured, within the range that was stated.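

Replacing fluoro with chloro on the core of compound 2 gives a 1.2-fold lower number from compound 2 to compound 4 (0.10 log units; within the scatter) in this assay, so this step, like the earlier one, cannot be told apart from the usual scatter of repeated measurements. Set beside the same change on the core of compound 3, the new step gives no sign that the exchange behaves differently on the two cores: the same change on two cores in this assay, a 1.6-fold lower number (0.21 log units; within the scatter) from compound 3 to compound 1 and a 1.2-fold lower number (0.10 log units; within the scatter) from compound 2 to compound 4, 1.3-fold (0.11 log units) apart, within the scatter of two such steps This shows only that the exchange carries from one core to the other without any detectable departure; it does not show that chloro and fluoro differ at all at this place in this assay, and two small steps on two cores support no rule for the wider series.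

The compounds shown leave open whether another group on this aromatic carbon, such as bromo, a methoxy group, a nitrile or an amine, would move the value beyond the scatter. They also leave open whether the exchange would give a similar step on a core without the trifluoromethyl group, or on cells other than those used in this assay.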